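Hexyloxy for Hexylsulfanyl in a Cytotoxicity Test

This account rests on a few compounds, and the source may have more. Where it says the series, first, only, none or still open, it means among the compounds named here.

Of the compounds shown here, two with a shared core have been measured in an ADME assay on MOLT-3 cells (Homo sapiens) for cytotoxicity, with a stated time of 7 days; on this read-out lower numbers stand for higher toxicity in this test and higher numbers for lower toxicity in this test. In this test, compound 1 `Nc1nc(OCC(F)(F)F)c2ncn(/C=C3/CC3(CO)CO)c2n1` gives > 20000 nM, which is a limit of the assay and not a number. Compound 2 `CCCCCCSc1nc(N)nc2c1ncn2/C=C1/CC1(CO)CO` gives > 20000 nM, which is also only a limit. The record so far is therefore (the limit of > 20000 nM in this assay, at which 2 of the 2 values shown sit).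

Compound 3 `CCCCCCOc1nc(N)nc2c1ncn2/C=C1/CC1(CO)CO` keeps the core of compound 2 and carries hexyloxy in place of hexylsulfanyl on an aromatic carbon. Among the compounds with values here, the one measured step that bears on this change, a step that the two limits leave unreadable from compound 1 to compound 2, also swaps the group on that aromatic carbon, but it offers no size to carry over. With no measured number to work from, no step beyond the usual scatter is expected in this assay, and another limit is the likeliest report. Expressed as a step, the estimate is a number no higher from compound 2 to compound 3 (the limit leaves the size open), which remains an expectation. Compound 3 is expected at 20000 nM, with an estimated range from 9000 nM to 40000 nM.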

Compound 3, half-maximal cytotoxic concentration: > 20000 nM
Compound 3 was reported as a limit; the forecaster's own chance of this, stated with the estimate: 75%; the middle value sits exactly at the limit.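

No step can be read between compound 1, compound 2 and compound 3, because each is reported in this assay only as a limit of the assay and not as a number: the limit of > 20000 nM in this assay, at which 3 of the 3 values shown sit.

The compounds shown leave open whether 2,2,2-trifluoroethoxy, hexylsulfanyl or hexyloxy on that aromatic carbon makes any difference to the read-out, and how large any such difference would be.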